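A few compounds are considered here, and "the series" means these few. Any claim that something is new, unique, unknown or untested is made for them only; others in the source may bear on it.

The series shares the core of compound 1 `O=C(NCc1ccc(S(=O)(=O)c2cncc(C(F)(F)F)c2)cc1)N1Cc2ccncc2C1` and varies only the group on a sulfonyl sulfur. In an assay on isolated protein for inhibition of Nicotinamide phosphoribosyltransferase (Homo sapiens), read by mass spectrometry, with stated times of 15 min and 30 min (a lower number here means a stronger inhibitor, a higher number a weaker inhibitor), compound 1 gives 15 nM. Compound 2 `O=C(NCc1ccc(S(=O)(=O)c2cc(F)cc(F)c2)cc1)N1Cc2ccncc2C1` gives 7.1 nM, and compound 3 `O=C(NCc1ccc(S(=O)(=O)C2CCC(F)(F)CC2)cc1)N1Cc2ccncc2C1` gives 78 nM. Compound 2 has the lowest number of the three: a 2.1-fold lower number from compound 1 to compound 2 (0.32 log units; beyond the scatter), while an 11-fold higher number from compound 2 to compound 3 (1.04 log units; beyond the scatter). Between the other two, a 5.2-fold higher number from compound 1 to compound 3 (0.72 log units; beyond the scatter).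

Compound 4 `CN1CCC(S(=O)(=O)c2ccc(CNC(=O)N3Cc4ccncc4C3)cc2)CC1` has not yet been measured. Relative to compound 2 the change is 1-methylpiperidin-4-yl in place of 3,5-difluorophenyl on a sulfonyl sulfur. The entering group is, like the 4,4-difluorocyclohexyl of compound 3, a six-membered non-aromatic ring on the same sulfonyl sulfur, so the step from compound 2 to compound 3 is the nearest guide, and the step from compound 1 to compound 3 points the same way. Both ran toward higher numbers and lay beyond the scatter, so a step toward a higher number is expected for compound 4 too, of roughly the size seen for compound 3. Among the measured compounds shown here, the data hold no step covering a hetero atom in the ring or an entering hydrogen-bond acceptor; the range is therefore set wide. The expected step is a 13-fold higher number from compound 2 to compound 4 (1.10 log units; beyond the scatter). Compound 4 is estimated at 90 nM in this assay, with a likely range from 30 nM to 300 nM.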

Compound 4, half-maximal inhibitory concentration: 48 nM
For compound 4 the middle estimate is 1.9-fold (0.27 log units) above the measured one, within the range that was stated.
By their numbers in this assay, from the lowest: compound 2; then compound 1; then compounds 4 and 3 (each within the scatter of the next).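

At this place on a sulfonyl sulfur, 1-methylpiperidin-4-yl brings a hetero atom and a hydrogen-bond acceptor into a non-aromatic ring, and in this assay it still gives higher numbers than both aromatic groups (a 6.8-fold higher number from compound 2 to compound 4 (0.83 log units; beyond the scatter); a 3.2-fold higher number from compound 1 to compound 4 (0.51 log units; beyond the scatter)). Against the other non-aromatic ring the result is a 1.6-fold lower number from compound 3 to compound 4 (0.21 log units; within the scatter), so 1-methylpiperidin-4-yl and 4,4-difluorocyclohexyl cannot be told apart here, and the ring hetero atom and acceptor give no detectable gain or loss over that group. Among these four compounds the two aromatic groups stand at lower numbers than the two non-aromatic rings, with no compound going against this, but nothing on hand accounts for the pattern.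

Still open, from the compounds shown here alone, is how a piperidin-4-yl with a free ring amine, a tetrahydropyran-4-yl or an acetylpiperidin-4-yl would read at this place, which would separate the role of the ring nitrogen from that of its methyl. Also open, going by these compounds, is whether a carboxylic acid or a longer chain on the non-aromatic ring would keep these numbers, and whether the aromatic-over-non-aromatic order extends beyond these four groups.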